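Extending the Pentyl Chain to Heptyl in a Urea Pair

This account rests on a few compounds, and the source may have more. Where it says the series, first, only, none or still open, it means among the compounds named here.

Compound 1 `CC(C)c1ccc(NC(=O)N[C@@H](C)c2ccccc2)cc1` and compound 2 `CCCCCc1ccc(NC(=O)N[C@@H](C)c2ccccc2)cc1` share one core and differ only in the chain on an aromatic carbon. In an ADME assay on the whole organism with Oryza sativa as the target, tested at 1 uM (a higher number here means a weaker effect of the compound at the concentration tested, a lower number a stronger effect), compound 1 gives 96%, and compound 2 gives 98%. Of these two numbers compound 2 stands highest, with compound 1 as its nearest neighbour, and the two cannot be told apart. Compound 3 `CCCCCCCc1ccc(NC(=O)N[C@@H](C)c2ccccc2)cc1` has not yet been measured in this assay. It carries ethyl in place of hydrogen on a saturated chain carbon, five bonds along the chain from an aromatic carbon. Within the data shown here, the only measured step that bears on this change is a number 2 percentage points higher from compound 1 to compound 2 (within the scatter), a change of chain length that left the read-out where it was. Since compound 2 already stands near the top of the scale, the step to compound 3 is expected to be a number 1 percentage points lower from compound 2 to compound 3 (within the scatter), nothing beyond the scatter. Compound 3 is therefore estimated at 97%, between 88% and 100%.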

Compound 3, a percentage reported as activity, at one concentration (the size of the read-out at that concentration, not a potency): 99%
For compound 3 the middle estimate is 2 percentage points below the measured one, within the range that was stated.
By their numbers in this assay, from the lowest: compounds 1, 2 and 3 (each within the scatter of the next).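

At this position, ethyl in place of hydrogen gives a number 1 percentage points higher from compound 2 to compound 3 (within the scatter) in this assay, so extending the chain beyond pentyl yields a read-out that cannot be told apart from that of compound 2. The direct comparison of the isopropyl and heptyl chains gives a number 3 percentage points higher from compound 1 to compound 3 (within the scatter), which shows that even the widest change among these chains leaves the three compounds indistinguishable in this assay. No evidence is available that bears on this result.

The compounds shown leave open whether any change to this chain can produce a clearly lower number in this assay, since all three lie within the scatter of one another. An amine or a carboxylic acid at the end of the chain, or a longer chain than heptyl, remains an open case.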